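This account rests on a few compounds, and the source may have more. Where it says the series, first, only, none or still open, it means among the compounds named here.

Measured so far:
compound 1 `O=C(O)CC1COc2cc(OCc3nc(-c4ccccc4)cs3)ccc21` — 0.16%
compound 2 `Cc1nc(-c2ccccc2)oc1COc1ccc2c(c1)OCC2CC(=O)O` — 7.15%
compound 3 `Cc1nc(-c2cccc3ccccc23)sc1COc1ccc2c(c1)OCC2CC(=O)O` — 8.53%

All three numbers come from a functional assay on CHO cells for agonist activity at Free fatty acid receptor 1 (Homo sapiens), read by FLIPR and calcium flux, tested at 100 nM; on this read-out lower numbers stand for a weaker effect and higher numbers for a stronger effect at the one concentration tested. Compound 3 shows the highest of the three numbers, but the gap to compound 2 and the gap to compound 1 both lie within the scatter of repeated measurements, so no order among the three can be claimed. The series as a whole sits at the low end of the read-out.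

Compound 4 `Cc1nc(-c2ccccc2C(F)(F)F)sc1COc1ccc2c(c1)OCC2CC(=O)O` is not yet measured. Relative to compound 3 the change is 2-(trifluoromethyl)phenyl in place of naphthalen-1-yl on an aromatic carbon. The methyl group on the five-membered ring and the shared core are kept. Going by the values given here, no measured pair in the set differs only at this position, so the size of the step has to be guessed from the general level of the three numbers, all of which are low and mutually within the scatter.

The expectation is that the step from compound 3 to compound 4, a number 3.5 percentage points lower from compound 3 to compound 4 (within the scatter), stays within the scatter, with no direction that can be read from the present numbers. Compound 4 is therefore estimated at 5%, with a range from 0% to 18% in this assay.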

Compound 4, a percentage reported as activity, at one concentration (the size of the read-out at that concentration, not a potency): 7.76%
For compound 4 the middle estimate is 2.8 percentage points below the measured one; measured number inside the range.
By their numbers in this assay, from the lowest: compounds 1, 2, 4 and 3 (each within the scatter of the next).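

In this assay, going by these compounds alone, 2-(trifluoromethyl)phenyl in place of naphthalen-1-yl gives a number 0.8 percentage points lower from compound 3 to compound 4 (within the scatter) and provides the first direct reading at this position, on an aromatic carbon of the five-membered aromatic ring with 1 nitrogen and 1 sulfur, with the methyl group and the shared core kept. The exchange replaces two six-membered aromatic rings of carbon only with one such ring, and the entering group carries fluorine while the leaving group holds carbon only, yet the read-out at the one concentration tested does not separate the two groups. Nothing at hand gives a reason for this result.

A single pair with two large aromatic groups does not show whether this position can move the read-out beyond the scatter at all, so the scope of this similarity remains undefined. An amine or a carboxylic acid on the aromatic ring at this position, or a longer chain in place of the ring, would test that question, while readings at one concentration leave potency itself open.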